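From an Aminophenyl to a Pyridyl Group on the Core

The source may report more compounds than this note shows. Statements on the series, on what has been measured and on what is new or still open speak of the compounds shown alone.

Of the compounds shown here, three sharing one core have been measured in an assay on LM cells for displacement of a labelled ligand from Neuropeptide Y receptor type 5 (Homo sapiens); on this read-out higher numbers stand for weaker inhibition and lower numbers for stronger inhibition. Compound 1 `Fc1ccc(C2(c3ccc(F)cc3)CNC(c3cccc(Cl)c3)=N2)cc1` gives 5.4 nM, and compound 2 `Fc1ccc(C2(c3ccc(F)cc3)CNC(c3cccc(F)c3)=N2)cc1` gives 10 nM; the step of a 1.9-fold higher number from compound 1 to compound 2 (0.27 log units; within the scatter) is small. Compound 3 `Nc1cccc(C2=NC(c3ccc(F)cc3)(c3ccc(F)cc3)CN2)c1` gives 300 nM, the highest number of the three, since the steps of a 56-fold higher number from compound 1 to compound 3 (1.74 log units; beyond the scatter) and a 30-fold higher number from compound 2 to compound 3 (1.48 log units; beyond the scatter) are both large.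

Compound 4 `Fc1ccc(C2(c3ccc(F)cc3)CNC(c3ccncc3)=N2)cc1` has not yet been measured. It differs from compound 3 in one place: pyridin-4-yl in place of 3-aminophenyl on a carbon with a double bond to nitrogen. In words, pyridin-4-yl stands in place of 3-aminophenyl on a carbon with a double bond to nitrogen. For the measured compounds named here, no measured step swaps an aromatic ring of carbon only for one with a ring nitrogen, so the steps that bear on this change are indirect. They show that the 3-aminophenyl of compound 3 goes with a much higher number than the chloro- or fluoro-bearing rings of compounds 1 and 2. Compound 4 removes the hydrogen-bond donor of that group but carries no halogen, so the expected step of a 5.0-fold lower number from compound 3 to compound 4 (0.70 log units; beyond the scatter) is downward yet short of a full return. The estimate for compound 4 in this assay is 60 nM, expected to lie between 12 nM and 300 nM.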

Compound 4, half-maximal inhibitory concentration: 160 nM
Beside the measured number, compound 4's estimate is 2.7-fold (0.43 log units) below it, and the stated range covers the measured number.
By their numbers in this assay, from the lowest: compounds 1 and 2 (each within the scatter of the next); then compounds 4 and 3 (each within the scatter of the next).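

In this assay, pyridin-4-yl in place of 3-aminophenyl gives a 1.9-fold lower number from compound 3 to compound 4 (0.27 log units; within the scatter) and so leaves the two groups within the scatter of each other, even though only 3-aminophenyl carries a hydrogen-bond donor. Both steps from the halogen-bearing rings are large, with a 16-fold higher number from compound 2 to compound 4 (1.20 log units; beyond the scatter) and a 30-fold higher number from compound 1 to compound 4 (1.47 log units; beyond the scatter) on the same read-out. Among these four compounds, then, the two rings with a halogen go with low numbers and the two without go with high numbers, and none of the four goes against this, but nothing measured here says why the numbers fall this way.

The compounds shown leave open how a plain phenyl ring with no added group would read at this carbon, which would show whether the halogen-bearing rings stand out or the other two fall behind. They also leave open whether a 3-methoxyphenyl or a 3-bromophenyl, or a pyridin-3-yl with its ring nitrogen in another place, would sit with the low numbers or the high numbers.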